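A Bulkier Aryl Group on a Shared Imide Core

The compounds below may be only part of what the source reports. "The series", "measured", "known", "first", "only" and "open" are said of these compounds alone.

Compound 2 `Cc1ccccc1Nc1ccc2c(c1)C(=O)N(C1CCC(=O)NC1=O)C2=O` and compound 1 `CC(=O)c1ccc(Nc2ccc3c(c2)C(=O)N(C2CCC(=O)NC2=O)C3=O)cc1` share one core and differ only in the group carried on the aromatic nitrogen. In an assay on FRT-Jurkat cells for inhibition of nuclear factor NF-kappa-B complex (Homo sapiens), read by flow cytometry, with a stated time of 24 h, tested at 10 uM (on this read-out higher numbers stand for more inhibition at the one concentration tested (going by the name of the read-out) and lower numbers for less inhibition), compound 2 gives 2%, and compound 1 gives -2%; the two numbers lie within the scatter of each other, so neither stands apart. Going by the values given here, the single measured step, a number 4 percentage points higher from compound 1 to compound 2 (within the scatter), is the only guide available. Compound 3 `CC(C)(C)c1ccc(Nc2ccc3c(c2)C(=O)N(C2CCC(=O)NC2=O)C3=O)cc1` is not yet measured. It differs from compound 2 in one place: 4-(tert-butyl)phenyl in place of 2-methylphenyl on a nitrogen on an aromatic ring. Among the compounds with values here, the earlier exchange of one aromatic group for another left the read-out essentially unmoved, and no other step exists to suggest otherwise, so the expected step is no change at the digits printed from compound 2 to compound 3 (within the scatter), staying within the scatter. Compound 3 is therefore estimated at 2%, with a range from -10% to 14%.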

Compound 3, a percentage reported as inhibition, at one concentration (the size of the read-out at that concentration, not a potency): 17%
Compound 3: middle estimate off by 15 percentage points, on the low side; measured number above the stated range.
By their numbers in this assay, from the lowest: compounds 1 and 2 (each within the scatter of the next); then compound 3.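

The group on the aromatic nitrogen can move the read-out after all: in this assay the change to 4-(tert-butyl)phenyl gives a number 15 percentage points higher from compound 2 to compound 3 (beyond the scatter) and so produces a step beyond the scatter, which the exchange between the two earlier aryl groups did not. Compound 1 and compound 3 differ only in the group on an aromatic carbon of that aryl ring, and tert-butyl in place of acetyl gives a number 19 percentage points higher from compound 1 to compound 3 (beyond the scatter) as a second step of this kind. No available evidence bears on the reason for these rises.

As far as these compounds go, it remains open whether tert-butyl is special, or whether other groups in its place, such as isopropyl, trifluoromethyl or a dimethylamino group, would give a similar number. From the compounds shown here alone, with compound 3 at 17% at a single concentration, its potency also remains open.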